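Aromatic Ring Returns on the Ether Oxygen

The compounds below may be only part of what the source reports. "The series", "measured", "known", "first", "only" and "open" are said of these compounds alone.

Three compounds share one core and differ only in the group attached to it. Compound 1 `Cc1cc(Sc2ccncc2)c(S(C)(=O)=O)cc1C(=O)N=C(N)N` carries a (pyridin-4-yl)sulfanyl group there and in a functional assay for inhibition of sodium/hydrogen exchanger (Oryctolagus cuniculus) (on this read-out higher numbers stand for weaker inhibition and lower numbers for stronger inhibition), compound 1 gives 13 nM. Compound 2 `Cc1cc(OC(C)C)c(S(C)(=O)=O)cc1C(=O)N=C(N)N` carries an isopropoxy group, and compound 2 gives 19 nM. Compound 3 `Cc1cc(OC2CCCC2)c(S(C)(=O)=O)cc1C(=O)N=C(N)N` carries a cyclopentyloxy group, and compound 3 gives 27 nM, the highest of the three numbers. Set against the other two, a 1.4-fold higher number from compound 2 to compound 3 (0.15 log units; within the scatter) lies within the scatter, whereas a 2.1-fold higher number from compound 1 to compound 3 (0.32 log units; beyond the scatter) is modest but beyond it.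

Compound 4 `Cc1cc(Oc2cccc(Cl)c2)c(S(C)(=O)=O)cc1C(=O)N=C(N)N` has not yet been measured. It differs from compound 3 in one place: 3-chlorophenyl in place of cyclopentyl on an oxygen on an aromatic ring. Two earlier steps bear on this. Exchanging isopropyl for cyclopentyl on that oxygen changed little, as a 1.4-fold higher number from compound 2 to compound 3 (0.15 log units; within the scatter) shows. Moving from the (pyridin-4-yl)sulfanyl group of compound 1, the only aromatic substituent seen so far, to cyclopentyloxy raised the number modestly, a 2.1-fold higher number from compound 1 to compound 3 (0.32 log units; beyond the scatter). Bringing an aromatic ring back onto this position is therefore expected to give, if anything, a small move toward a lower number, with a 1.8-fold lower number from compound 3 to compound 4 (0.26 log units; within the scatter) estimated to stay close to the scatter. Compound 4 is expected to give 15 nM, within a range of 6 nM to 40 nM.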

Compound 4, half-maximal inhibitory concentration: 21 nM
Compound 4: the middle estimate sits 1.4-fold (0.15 log units) below what was measured; the measured number falls inside the stated range.
By their numbers in this assay, from the lowest: compounds 1, 2, 4 and 3 (each within the scatter of the next, the first and the last beyond it).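

Placing 3-chlorophenyl on the oxygen, where only non-aromatic groups had stood, gives a 1.3-fold lower number from compound 3 to compound 4 (0.11 log units; within the scatter) in this assay, and the comparison with isopropyl gives a 1.1-fold higher number from compound 2 to compound 4 (0.04 log units; within the scatter). Neither step can be told apart from the scatter, so this oxygen has now carried a branched chain, a five-membered non-aromatic ring and a six-membered aromatic ring bearing chlorine with no measurable difference among them, even as the group grows from cyclopentyl's 5 heavy atoms to 7. The change from the sulfur-linked pyridine of the core of compound 1 to 3-chlorophenoxy also stays inside the scatter, at a 1.6-fold higher number from compound 1 to compound 4 (0.21 log units; within the scatter), so replacing both the linking atom and the ring leaves no measurable mark in this pair.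

The compounds shown leave open how a plain phenyl without its chlorine would compare, and whether a carboxylic acid or an amine at the end of a longer chain on this oxygen would shift the number where these groups did not. Nothing available explains why these groups read so alike.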